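A few compounds are considered here, and "the series" means these few. Any claim that something is new, unique, unknown or untested is made for them only; others in the source may bear on it.

Three ureas built on one shared core have been tested in a functional assay on CRL2813 cells (Homo sapiens) for cytotoxicity, read by sulforhodamine B assay, with a stated time of 5 days; a higher number here means a weaker inhibitor, a lower number a stronger inhibitor. Compound 1 `O=C(Nc1cccc(F)c1)N[C@H]1CC[C@H](Oc2ccc(F)cc2)CC1` gives 8300 nM. Compound 2 `O=C(Nc1ccc([N+](=O)[O-])cc1)N[C@H]1CC[C@H](Oc2ccc(F)cc2)CC1` gives 2300 nM. Among the compounds with values here, compound 3 `O=C(Nc1ccccc1Br)N[C@H]1CC[C@H](Oc2ccc(F)cc2)CC1` gives 7700 nM, the second highest of the three numbers: its gap to compound 1 lies within the scatter, and the only step beyond the scatter is a 3.3-fold higher number from compound 2 to compound 3 (0.52 log units; beyond the scatter).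

Compound 4 `COc1ccc(NC(=O)N[C@H]2CC[C@H](Oc3ccc(F)cc3)CC2)cc1` differs from compound 3 by 4-methoxyphenyl in place of 2-bromophenyl on an amide-type nitrogen. Two measured steps also swap the group on the amide-type nitrogen: a 1.1-fold lower number from compound 1 to compound 3 (0.03 log units; within the scatter) and a 3.3-fold higher number from compound 2 to compound 3 (0.52 log units; beyond the scatter). Such swaps have shifted the number by at most a modest amount, so a step of similar or smaller size is expected in this assay, with no clear direction. Compound 4 is therefore estimated at 6000 nM, within 2500 nM to 15000 nM, meaning an expected 1.3-fold lower number from compound 3 to compound 4 (0.11 log units; within the scatter).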

Compound 4, half-maximal inhibitory concentration: > 20000 nM
Compound 4: a limit, no number; the forecaster's own chance of this, stated with the estimate: 10%; middle value at least 3.3-fold (0.52 log units) away from the limit.
By their numbers in this assay, from the lowest: compound 2; then compounds 3 and 1 (each within the scatter of the next). At a limit, above all of these: compound 4.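

Compound 4 gives a limit, not a number: the limit of > 20000 nM in this assay, at which 1 of the 4 values shown sits. The earlier swaps on this amide-type nitrogen had shifted the number only modestly, but here the change is larger: an at least 2.5-fold higher number from compound 3 to compound 4 (0.41 log units; beyond the scatter), an at least 2.4-fold higher number from compound 1 to compound 4 (0.38 log units; beyond the scatter) and, for methoxy in place of nitro on an aromatic carbon, an at least 8.6-fold higher number from compound 2 to compound 4 (0.93 log units; beyond the scatter). This position can therefore take the number out of the measurable range, and the choice of group matters more than compounds 1 to 3 showed.

On these data alone, the true size of these steps stays open. So does the outcome with an amine or a carboxylic acid in place of methoxy on that aromatic carbon.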